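Adding a methoxy to the sulfonyl-linked phenyl of compound 1

A few compounds are considered here, and "the series" means these few. Any claim that something is new, unique, unknown or untested is made for them only; others in the source may bear on it.

Compound 1 `CC1CCN(c2c(S(=O)(=O)c3ccccc3)cnc3ccc(F)cc23)CC1` has the lowest number of the three measured compounds in an assay on isolated protein for displacement of a labelled ligand from metabotropic glutamate receptor 5 (Homo sapiens), with a stated time of 60 min, tested at 1 uM (on this read-out lower numbers stand for less inhibition and higher numbers for more inhibition at the one concentration tested (going by the name of the read-out)), where compound 1 gives 40%. Compound 2 `Cc1ccc2ncc(S(=O)(=O)c3ccccc3)c(N3CCC(C)CC3)c2c1` gives 67% in this assay, and compound 3 `Cc1ccc2ncc(S(=O)(=O)c3cc(Cl)cc(Cl)c3)c(N3CCC(C)CC3)c2c1` gives 75%. The step of a number 27 percentage points higher from compound 1 to compound 2 (beyond the scatter) changes the substituent on the shared core and is beyond the scatter, whereas the step of a number 8 percentage points higher from compound 2 to compound 3 (within the scatter), which alters the phenyl on the sulfonyl sulfur, lies within the scatter.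

The unmeasured compound 4 `COc1cccc(S(=O)(=O)c2cnc3ccc(F)cc3c2N2CCC(C)CC2)c1` differs from compound 1 by methoxy in place of hydrogen on an aromatic carbon. This change sits on the same phenyl that was altered between compound 2 and compound 3, and the substituent on the shared core is kept as in compound 1, so the step from compound 1 to compound 2 does not bear on it. Going by the values given here, the only related comparison, from compound 2 to compound 3, moved the read-out by an amount within the scatter. Compound 4 is therefore expected to show a step of a number 5 percentage points higher from compound 1 to compound 4 (within the scatter), small and not clearly beyond the scatter. The estimate for compound 4 in this assay is 45%, with a range from 25% to 65%.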

Compound 4, a percentage reported as inhibition, at one concentration (the size of the read-out at that concentration, not a potency): 90%
The estimate for compound 4 lay 45 percentage points below the measured number, outside the stated range (above it).
By their numbers in this assay, from the lowest: compound 1; then compounds 2 and 3 (each within the scatter of the next); then compound 4.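

In this assay, the phenyl on the sulfonyl sulfur turns out to be a place where one small addition can count: methoxy in place of hydrogen, on an aromatic carbon meta to a large group, gives a number 50 percentage points higher from compound 1 to compound 4 (beyond the scatter) and so marks a large step. The only earlier change on this phenyl, 3,5-dichlorophenyl in place of phenyl, gave a number 8 percentage points higher from compound 2 to compound 3 (within the scatter) on the core carrying methyl, so the earlier compounds had shown no change on this ring that went beyond the scatter, and none on the core carrying fluoro. Going by these compounds alone, nothing measured here explains why this one change moves the number so far.

Going by these compounds, it remains open whether the gain belongs to methoxy itself or would also appear with a hydroxyl, an amine or a longer chain such as ethoxy at the same place on the ring. On these data alone, it also remains open whether 3-methoxyphenyl would give a step of similar size on the core of compound 2, or whether the step holds only with the fluoro of compound 1.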